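Chloro to Methylsulfanyl: Expected Cytotoxicity of Compound 4

The compounds below may be only part of what the source reports. "The series", "measured", "known", "first", "only" and "open" are said of these compounds alone.

Measured so far:
- compound 1, `O=c1[nH]c(=O)n([C@H]2C[C@H](O)[C@@H](CO)O2)cc1-c1cn(-c2cc(F)cc(F)c2)nn1`, 220000 nM
- compound 2, `CC(C)c1ccc(-n2cc(-c3cn([C@H]4C[C@H](O)[C@@H](CO)O4)c(=O)[nH]c3=O)nn2)cc1`, > 240000 nM
- compound 3, `O=c1[nH]c(=O)n([C@H]2C[C@H](O)[C@@H](CO)O2)cc1-c1cn(-c2ccc(Cl)cc2)nn1`, > 240000 nM

In an ADME assay on HEL cells (Homo sapiens) for cytotoxicity, read by cell counting, with a stated time of 3 days (a lower number here means that less compound is tolerated, a higher number that more compound is tolerated), compound 3 gives only a limit, not a number. The same holds for compound 2, whose value is also a limit. Going by the values given here, compound 1 is the only one with a measured number. Among the compounds with values here, of the three values shown, two sit at the ceiling of the assay (the limit of > 240000 nM in this assay, at which 2 of the 3 values shown sit), so the compounds so far are tolerated up to the highest concentration tested.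

The measured steps are small. From compound 1 the change is an at least 1.0-fold higher number from compound 1 to compound 2 (0.03 log units; that floor lies within the scatter) and an at least 1.0-fold higher number from compound 1 to compound 3 (0.03 log units; that floor lies within the scatter), both floors lying within the usual scatter. The step that the two limits leave unreadable from compound 2 to compound 3 cannot be read, since both ends are limits.

Compound 4, `CSc1ccc(-n2cc(-c3cn([C@H]4C[C@H](O)[C@@H](CO)O4)c(=O)[nH]c3=O)nn2)cc1`, differs from compound 3 by methylsulfanyl in place of chloro on an aromatic carbon. Since the steps within this series have all stayed within scatter or at the ceiling, no step beyond the scatter is expected in this assay for compound 4; the step of a number no higher from compound 3 to compound 4 (the limit leaves the size open) is the expectation. Compound 4 is therefore estimated to give 240000 nM, within 120000 nM to 480000 nM, most likely again as a limit.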

Compound 4, minimum cytotoxic concentration: > 230000 nM
Compound 4: a limit, no number (the forecaster's own chance of this, stated with the estimate: 65%); the middle value does not contradict the limit.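

In this assay, compound 4 gives a limit and not a number, which is what methylsulfanyl brings to this aromatic carbon, para to a large group: the limit of > 230000 nM in this assay, at which 1 of the 4 values shown sits.

Its steps to compound 2 and compound 3 have limits at both ends and cannot be read. Going by these compounds alone, the only readable comparison is an at least 1.0-fold higher number from compound 1 to compound 4 (0.01 log units; that floor lies within the scatter), so methylsulfanyl, like chloro and isopropyl before it at this place, shows no step beyond the scatter from the 3,5-difluorophenyl compound.

Going by these compounds, whether an amine or a carboxylic acid on this carbon would give a number rather than a limit stays open. On these data alone, the size of any differences among compound 2, compound 3 and compound 4 also stays open, since all three values are limits.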